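The source may hold more compounds than are shown below. What is called first, only, known or untested is meant among the compounds shown, and "the series" means these compounds.

Compound 1 `COc1cc(C)cc(-c2nn(CC#N)cc2-c2ccc(-c3cccc(C(C)=O)c3)nc2)c1` gives 6720 nM
Compound 2 `Cc1cc(O)cc(-c2nn(CC#N)cc2-c2ccnc(-c3ccc(Oc4ccccc4)cc3)c2)c1` gives 10400 nM
Compound 3 `COc1cc(C)cc(-c2nn(CC#N)cc2-c2ccnc(-c3ccc(N(C)C)cc3)c2)c1` gives 492 nM

All three were measured in a functional assay on NCI-H522 cells (Homo sapiens) for inhibition, read by sulforhodamine B assay, with a stated time of 48 h; a lower number here means a stronger inhibitor of growth, a higher number a weaker inhibitor of growth. Compound 3 stands at the lowest of the three numbers and is therefore the strongest inhibitor of growth among them: compound 1 lies well above it, beyond the usual scatter, and compound 2 lies higher still, also beyond the scatter. The three compounds share a core but differ from one another in more than one place, so no single change among them can be read off on its own.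

Compound 4 `Cc1cc(O)cc(-c2nn(CC#N)cc2-c2ccnc(-c3ccc(N(C)C)cc3)c2)c1` is the next compound. It differs from compound 3 in one place only: hydrogen in place of methyl on an oxygen on an aromatic ring. The rest of the molecule, including the dimethylamino-bearing ring on the other side of the core, is kept. Going by the values given here, no pair of measured compounds shows this exact change by itself, so its effect has to be guessed. A change of this kind, a single carbon removed at the edge of the molecule, is expected to move the number only a little, with a modest weakening the more likely direction. The expected step, a 1.5-fold higher number from compound 3 to compound 4 (0.18 log units; within the scatter), is accordingly small. Compound 4 is expected to give about 750 nM, within a range from 250 nM to 2500 nM.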

Compound 4, concentration for total growth inhibition: 7140 nM
Compound 4: middle estimate off by 9.5-fold (0.98 log units), on the low side; measured number outside the range, above it.
By their numbers in this assay, from the lowest: compound 3; then compounds 1, 4 and 2 (each within the scatter of the next).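

In this assay the change from methoxy to hydroxy on the 3-methoxy-5-methylphenyl group proves far from minor: a 15-fold higher number from compound 3 to compound 4 (1.16 log units; beyond the scatter) is a large step, so this position is highly sensitive to the loss of one methyl from the oxygen. The second step shows something different. With hydroxy in place, a 1.5-fold lower number from compound 2 to compound 4 (0.16 log units; within the scatter) stays within the scatter, so dimethylamino in place of phenoxy makes no readable difference between these two compounds. Taken together, the two steps show that the dimethylamino group does not give a low number on its own in this pair, and that the low number of compound 3 goes with its methoxy group; no measurement at hand explains why the step is so large.

As far as these compounds go, it remains open whether a longer chain on that oxygen, such as ethoxy, or a fluorine or an amine in place of methoxy, would keep the number near that of compound 3. From the compounds shown here alone, it is equally open whether methoxy in place of hydroxy would lower the number as sharply with phenoxy in place of dimethylamino.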